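Removing the para-fluorine from the second aryl group

The source may report more compounds than this note shows. Statements on the series, on what has been measured and on what is new or still open speak of the compounds shown alone.

Measured compounds:
Compound 1, `COc1cccc(-c2nc(C(F)(F)F)n(CC[C@@H](O)C[C@@H](O)CC(=O)O)c2-c2ccc(F)cc2)c1`: 20 nM
Compound 2, `O=C(O)C[C@H](O)C[C@H](O)CCn1c(C(F)(F)F)nc(-c2ccc(F)cc2)c1-c1ccc(F)cc1`: 38 nM
Compound 3, `COc1ccc(-c2nc(C(F)(F)F)n(CC[C@@H](O)C[C@@H](O)CC(=O)O)c2-c2ccc(F)cc2)cc1`: 68 nM

In an assay on microsomes from liver for inhibition of 3-hydroxy-3-methylglutaryl-coenzyme A reductase (Rattus norvegicus) (a lower number here means a stronger inhibitor, a higher number a weaker inhibitor), compound 2 sits second highest of the three numbers, with compound 3 at a 1.8-fold higher number from compound 2 to compound 3 (0.25 log units; within the scatter) and compound 1 at a 1.9-fold higher number from compound 1 to compound 2 (0.28 log units; within the scatter), both within the scatter. Going by the values given here, the only step beyond the scatter is a 3.4-fold higher number from compound 1 to compound 3 (0.53 log units; beyond the scatter), and it concerns the methoxy position on the other aryl group, not the fluorine in question.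

Compound 4, `O=C(O)C[C@H](O)C[C@H](O)CCn1c(C(F)(F)F)nc(-c2ccc(F)cc2)c1-c1ccccc1`, differs from compound 2 by hydrogen in place of fluoro on an aromatic carbon. Among the compounds with values here, no measured step removes this fluorine; the nearest is the exchange of fluoro for methoxy at the same place, a 1.8-fold higher number from compound 2 to compound 3 (0.25 log units; within the scatter), which stayed within the scatter. Within the data shown here, that is the only evidence bearing on the change, and it points to a small or no effect. On this basis compound 4 is expected to show a 1.4-fold higher number from compound 2 to compound 4 (0.16 log units; within the scatter), a step not beyond the scatter. The estimate for compound 4 in this assay is 55 nM, ranging from 20 nM to 150 nM.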

Compound 4, half-maximal inhibitory concentration: 201 nM
Compound 4: middle estimate off by 3.7-fold (0.56 log units), on the low side, outside the stated range (above it).
By their numbers in this assay, from the lowest: compounds 1, 2 and 3 (each within the scatter of the next, the first and the last beyond it); then compound 4.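

In this assay, replacing the fluorine with hydrogen gives a 5.3-fold higher number from compound 2 to compound 4 (0.72 log units; beyond the scatter), so this position responds to the change from 4-fluorophenyl to phenyl far more clearly than the earlier exchange suggested. That exchange, fluoro to methoxy at the same place, gave a 1.8-fold higher number from compound 2 to compound 3 (0.25 log units; within the scatter), so the flat result for methoxy did not mean that the group could be dropped altogether. The data on hand offer no explanation for the weaker inhibition of the unsubstituted phenyl compound.

Still open, from the compounds shown here alone, is whether other groups at this place, such as chlorine, methyl or a hydroxyl group, would keep the number near that of compound 2. Going by these compounds, it is also open whether removing this fluorine costs as much when the other aryl group is 3-methoxyphenyl, as in compound 1.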